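This account rests on a few compounds, and the source may have more. Where it says the series, first, only, none or still open, it means among the compounds named here.

Measured so far in an assay on CHO cells for displacement of a labelled ligand from adenosine receptor A1 (Homo sapiens), read by scintillation counting, with a stated time of 3 h; a higher number here means a weaker inhibitor, a lower number a stronger inhibitor:

compound 1 `Nc1nc(-c2ccccc2)nc2sc(-c3ccccc3)nc12` — 148 nM
compound 2 `Nc1nc(-c2ccccc2)nc2sc(-c3ccco3)nc12` — 33 nM

Within the data shown here, compound 2 holds the lower of the two numbers; the one comparison available, a 4.5-fold lower number from compound 1 to compound 2 (0.65 log units; beyond the scatter), concerns a swap of the aryl group on the five-membered ring, and nothing else has been varied.

Compound 3 `COc1cccc(-c2nc(N)c3nc(-c4ccco4)sc3n2)c1` differs from compound 2 in one place: methoxy in place of hydrogen on an aromatic carbon, on an aromatic carbon of a six-membered aromatic ring of carbon only, meta to a large group. Among the measured compounds shown here, no measured step touches that ring; the step from compound 1 to compound 2 changes a different part of the molecule and so gives no guidance on a methoxy group here. With nothing to argue for a gain or loss, the working expectation for compound 3 is a step of no more than the usual scatter, a 1.1-fold higher number from compound 2 to compound 3 (0.03 log units; within the scatter), and an estimated value of 35 nM with a range of 10 nM to 120 nM.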

Compound 3, inhibition constant: 62.3 nM
Compound 3: middle estimate off by 1.8-fold (0.25 log units), on the low side; the range from low to high includes it.
By their numbers in this assay, from the lowest: compounds 2 and 3 (each within the scatter of the next); then compound 1.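

In this assay, methoxy in place of hydrogen on an aromatic carbon of the six-membered aromatic ring of carbon only, meta to a large group, gives a 1.9-fold higher number from compound 2 to compound 3 (0.28 log units; within the scatter). Among these compounds, this is the first reading at this ring, and it shows that a methoxy group can sit at this place without a step beyond the scatter, so this change separates neither compound from the other. No supporting measurement bears on this result, so it gives no explanation for the small step.

Going by these compounds, it remains open whether a hydroxyl, an amine or a longer alkoxy chain at the same place would also stay within the scatter of compound 2. On these data alone, it is also open whether methoxy elsewhere on this ring, or alongside phenyl in place of furan-2-yl, would read the same way.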